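Shortening the Alkyl Chain on an Acetylated Glycoside

The source may hold more compounds than are shown below. What is called first, only, known or untested is meant among the compounds shown, and "the series" means these compounds.

Measured compounds:
Compound 1, `CCCCCc1nnc(-c2ccc(O[C@@H]3O[C@H](COC(C)=O)[C@@H](OC(C)=O)[C@H](OC(C)=O)[C@H]3OC(C)=O)cc2)o1`: 21.5%
Compound 2, `O=C(N/N=C/c1ccc(F)cc1)c1ccc(O[C@@H]2O[C@H](CO)[C@@H](O)[C@H](O)[C@H]2O)cc1`: 9.91%
Compound 3, `Cc1ccc(/C=N/NC(=O)c2ccc(O[C@@H]3O[C@H](CO)[C@@H](O)[C@H](O)[C@H]3O)cc2)cc1`: 9.28%

In a functional assay on MDA-MB-231 cells (Homo sapiens) for inhibition, read by MTT assay, with a stated time of 24 h, tested at 100 uM (on this read-out lower numbers stand for less inhibition and higher numbers for more inhibition at the one concentration tested (going by the name of the read-out)), compound 1 gives the highest of the three numbers; compound 2 and compound 3 both lie beyond the scatter below it. Among the measured compounds shown here, the only measured step, a number 0.6 percentage points lower from compound 2 to compound 3 (within the scatter), concerns a different part of a different series and says nothing about the change now in view.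

Compound 4, `CC(=O)OC[C@H]1O[C@@H](Oc2ccc(-c3nnc(C(C)C)o3)cc2)[C@H](OC(C)=O)[C@@H](OC(C)=O)[C@@H]1OC(C)=O`, differs from compound 1 in one place: isopropyl in place of pentyl on an aromatic carbon. For the measured compounds named here, the pentyl chain is cut back to isopropyl, and no measured pair shows what such a shortening does in this assay. Without a guiding step, no change beyond the scatter is expected, so compound 4 is estimated at 18%, between 6% and 32%, a step of a number 3.5 percentage points lower from compound 1 to compound 4 (within the scatter).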

Compound 4, a percentage reported as inhibition, at one concentration (the size of the read-out at that concentration, not a potency): 11.9%
Estimate against measurement, compound 4: 6.1 percentage points above; the measured number falls inside the stated range.
By their numbers in this assay, from the lowest: compounds 3, 2, 4 and 1 (each within the scatter of the next, the first and the last beyond it).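

In this assay, among the compounds shown here, the change of pentyl to isopropyl gives a number 9.6 percentage points lower from compound 1 to compound 4 (within the scatter) and so offers the first reading at this position of the five-membered aromatic ring. Cutting the chain from 5 carbons to 3 here therefore leaves the number within what repeat measurements would show. No measurement at hand ties this step to any property of either group. Still open, going by these compounds, is whether a longer chain such as octyl, or an amine, on this same carbon would move the number beyond the scatter from compound 1.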